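The source may report more compounds than this note shows. Statements on the series, on what has been measured and on what is new or still open speak of the compounds shown alone.

Of the compounds shown here, two sharing one core have been measured in a functional assay on HCT-116 cells (Homo sapiens) for cytotoxicity, read by MTT assay, with a stated time of 72 h; on this read-out lower numbers stand for stronger inhibition and higher numbers for weaker inhibition. Compound 1 `COc1ccc(Nc2nc3ccccc3nc2S(=O)(=O)c2ccc(C)cc2)cc1` is known there only through a limit: in this assay compound 1 reads > 50000 nM, which is a limit of the assay and not a number. Going by the values given here, compound 2 `COc1ccc(S(=O)(=O)c2nc3ccccc3nc2Nc2ccccc2)cc1` is the single compound with a measured number, and in this assay compound 2 gives 1260 nM. Among the compounds with values here, compound 2 therefore stands as the only value shown, alongside one further entry that is a limit (the limit of > 50000 nM in this assay, at which 1 of the 2 values shown sits). Compound 3 `COc1ccc(Nc2nc3ccccc3nc2S(=O)(=O)c2ccc(OC)cc2)cc1` has not yet been measured. It differs from compound 2 in one place (methoxy in place of hydrogen on an aromatic carbon), methoxy in place of hydrogen on an aromatic carbon. Within the data shown here, no step between measured compounds is available, so the size of this change has no direct precedent; compound 1 and compound 2 differ in two places, and their two values show one limit and one number, nothing more. Compound 3 is expected to come out weaker than compound 2, with an estimated step of a 4.0-fold higher number from compound 2 to compound 3 (0.60 log units; beyond the scatter) beyond the usual scatter. Compound 3 is estimated at 5000 nM in this assay, with an expected range from 1000 nM to 50000 nM, and a real chance that only a limit is reported.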

Compound 3, half-maximal inhibitory concentration: 29100 nM
For compound 3 the middle estimate is 5.8-fold (0.76 log units) below the measured one; low and high end bracket the measured number.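

In this assay, the change from anilino to (4-methoxyphenyl)amino gives the first direct measure at this aromatic carbon, para to a large group: a 23-fold higher number from compound 2 to compound 3 (1.36 log units; beyond the scatter). Going by these compounds alone, this large step, beyond the scatter, shows that for this pair, methoxy in place of hydrogen at this position comes with a clear loss of inhibition, which the earlier compounds, differing in two places, could not isolate. The second step, with methoxy in place of methyl on an aromatic carbon, is an at least 1.7-fold lower number from compound 1 to compound 3 (0.23 log units; that floor lies within the scatter); its floor lies within the scatter, so it establishes no difference between these two compounds, and compound 1 remains known only through a limit of the assay: the limit of > 50000 nM in this assay, at which 1 of the 3 values shown sits.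

From the compounds shown here alone, only hydrogen and methoxy have been compared at this position, so it remains open whether fluorine, a hydroxyl, a methyl or an amine on the same carbon would read closer to compound 2 or to compound 3. Going by these compounds, it also remains open whether the step depends on the methoxy that compound 2 and compound 3 share at their other aromatic ring, or would be the same with a methyl there.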